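A few compounds are considered here, and "the series" means these few. Any claim that something is new, unique, unknown or untested is made for them only; others in the source may bear on it.

Of the compounds shown here, two carry numbers so far. Compound 1 `Cn1nc(CN2CCN(c3ccccc3)CC2)nc1-c1ccc(C(C)(C)C)cc1` gives 29.8 mL.min-1.g-1 in an ADME assay on microsomes from liver (Rattus norvegicus) for metabolic stability, read by LC-MS, using NADPH, with a stated time of 1 h, tested at 10 uM; a higher number here means faster removal of the compound, a lower number slower removal. Compound 2 `Cn1nc(CN2CCCC2)nc1-c1ccc(C2(C(F)(F)F)CC2)cc1` gives 207 mL.min-1.g-1 in this assay, the higher of the two numbers, with a gap to compound 1 that lies beyond the scatter. Compound 3 `Cn1nc(CN2CCCC2)nc1-c1ccc(C(C)(C)C)cc1` is not yet measured; it differs from compound 2 by tert-butyl in place of 1-(trifluoromethyl)cyclopropyl on an aromatic carbon. Among the measured compounds shown here, no measured pair isolates this change, since compound 1 also carries a different amine. A modest step down, a 1.9-fold lower number from compound 2 to compound 3 (0.27 log units; within the scatter), is expected, because compound 1 with tert-butyl gives 29.8 mL.min-1.g-1. Compound 3 is estimated at 110 mL.min-1.g-1, between 45 mL.min-1.g-1 and 250 mL.min-1.g-1.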

Compound 3, intrinsic clearance in microsomes: 72 mL.min-1.g-1
The estimate for compound 3 lay 1.5-fold (0.18 log units) above the measured number; measured number inside the range.
By their numbers in this assay, from the lowest: compound 1; then compound 3; then compound 2.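

In this assay, tert-butyl in place of 1-(trifluoromethyl)cyclopropyl gives a 2.9-fold lower number from compound 2 to compound 3 (0.46 log units; beyond the scatter), with the amine held constant. The group on this aromatic carbon thus moves the number on its own, which compound 1 and compound 2, differing in two places, could not show. No available data explain the step. As far as these compounds go, what a nitrile or a chlorine atom on this aromatic carbon would give remains open, as does whether the step recurs with the amine of compound 1.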